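Changing the group on the sulfonyl sulfur of compound 1

A few compounds are considered here, and "the series" means these few. Any claim that something is new, unique, unknown or untested is made for them only; others in the source may bear on it.

compound 1 `CNC(=O)c1cc(S(=O)(=O)N2CCS[C@H]2C(=O)O[C@@H](Cc2c(Cl)c[n+]([O-])cc2Cl)c2ccc(OC(F)F)c(OCC3CC3)c2)cn1C` gives 12.6 nm/s
compound 2 `COc1ccc(S(=O)(=O)N2CCCC[C@H]2C(=O)O[C@@H](Cc2c(Cl)c[n+]([O-])cc2Cl)c2ccc(OC(F)F)c(OCC3CC3)c2)cc1C(=O)N(C)C` gives 132 nm/s

In an ADME assay on Caco-2 cells (Homo sapiens) for permeability, read by LC-MS, in the apical to basolateral direction, with a stated time of 2 h, tested at 10 uM (a lower number here means that the compound crosses the layer more slowly, a higher number that the compound crosses the layer faster), compound 1 gives 12.6 nm/s, the lower of the two numbers and beyond the scatter from compound 2. Compound 3 `COc1ccc(S(=O)(=O)N2CCS[C@H]2C(=O)O[C@@H](Cc2c(Cl)c[n+]([O-])cc2Cl)c2ccc(OC(F)F)c(OCC3CC3)c2)cc1OC` differs from compound 1 on the sulfonyl sulfur: a group of 10 heavy atoms (8 carbon, 2 oxygen; one six-membered aromatic ring of carbon only) in place of a group of 10 heavy atoms (7 carbon, 2 nitrogen, 1 oxygen; one five-membered aromatic ring with 1 hetero atom), on a sulfonyl sulfur. Among the compounds with values here, no measured pair shows this change. The expectation rests on compound 2 at 132 nm/s, which also has a six-membered aromatic ring of carbon only on its sulfonyl sulfur. An upward step beyond the scatter is expected, a 9.5-fold higher number from compound 1 to compound 3 (0.98 log units; beyond the scatter), though with little certainty. For compound 3 the estimated value is 120 nm/s, with an expected range from 40 nm/s to 350 nm/s overall.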

Compound 3, apparent permeability: 2.5 nm/s
Estimate against measurement, compound 3: 48-fold (1.68 log units) above; the whole stated range lies above it.
By their numbers in this assay, from the lowest: compound 3; then compound 1; then compound 2.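

With the rest of compound 1 kept, placing 3,4-dimethoxyphenyl on the sulfonyl sulfur gives, in this assay, a 5.0-fold lower number from compound 1 to compound 3 (0.70 log units; beyond the scatter) and so shows that this group alone can move the number beyond the scatter. The change also swaps the ring type and removes the hydrogen-bond donor of the leaving group. No measurement available here accounts for the step.

Ring type and donor change together, so which of them matters stays open. A plain phenyl or a pyridine on the sulfonyl sulfur would help to separate them.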